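Adding One Carbon to a Side Chain

This account rests on a few compounds, and the source may have more. Where it says the series, first, only, none or still open, it means among the compounds named here.

Compound 1 `C=CC(=O)Nc1cccc(Oc2nc(Nc3cccc(C#N)c3)nc3c2CSCC3)c1` gives 34900 nM
Compound 2 `C/C=C/C(=O)Nc1cccc(Oc2nc(Nc3cccc(C#N)c3)nc3c2CSCC3)c1` gives 12800 nM

For the measured compounds named here, in a functional assay on HeLa cells (Homo sapiens) for antiproliferative activity, read by MTT assay, with a stated time of 72 h (on this read-out lower numbers stand for stronger inhibition and higher numbers for weaker inhibition), compound 2 gives 12800 nM and so holds the lower of the two numbers measured so far. Going by the values given here, the one measured step that bears on the next change is a 2.7-fold lower number from compound 1 to compound 2 (0.44 log units; beyond the scatter) and it came with prop-1-en-1-yl in place of vinyl on a carbonyl carbon. Compound 3 `CC/C=C/C(=O)Nc1cccc(Oc2nc(Nc3cccc(C#N)c3)nc3c2CSCC3)c1` carries a further change (methyl in place of hydrogen on a saturated chain carbon bound to a double-bonded chain carbon) with methyl in place of hydrogen on a saturated chain carbon bound to a double-bonded chain carbon, so prop-1-en-1-yl becomes but-1-en-1-yl. Among the compounds with values here, with a 2.7-fold lower number from compound 1 to compound 2 (0.44 log units; beyond the scatter) as the only guide, a small further fall in the number is expected, perhaps none beyond the scatter. The estimated change is a 1.3-fold lower number from compound 2 to compound 3 (0.11 log units; within the scatter) on this reasoning. For compound 3 the expected value in this assay is 10000 nM with an estimated range of 4000 nM to 25000 nM around it.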

Compound 3, half-maximal inhibitory concentration: 31800 nM
Beside the measured number, compound 3's estimate is 3.2-fold (0.50 log units) below it; measured number above the stated range.
By their numbers in this assay, from the lowest: compound 2; then compounds 3 and 1 (each within the scatter of the next).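

In this assay, lengthening the side chain on the carbonyl does not move the number steadily in one direction: methyl in place of hydrogen on a saturated chain carbon bound to a double-bonded chain carbon, which turns prop-1-en-1-yl into but-1-en-1-yl, gives a 2.5-fold higher number from compound 2 to compound 3 (0.40 log units; beyond the scatter). Set against vinyl, but-1-en-1-yl gives a 1.1-fold lower number from compound 1 to compound 3 (0.04 log units; within the scatter), so the fall seen with prop-1-en-1-yl does not carry over to the longer chain, and only compound 2 stands apart among the three. Nothing available here explains why one added carbon turns the step around.

A longer chain such as pent-1-en-1-yl, or a dimethylamino group at the end of the chain, could show whether compound 2 marks a real low point in this series. As far as these compounds go, whether the same steps would hold on a different core also remains open.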